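The compounds below may be only part of what the source reports. "The series", "measured", "known", "first", "only" and "open" are said of these compounds alone.

Of the compounds shown here, two built on a shared core have been measured. Compound 1 `COc1cc2cc(Oc3ccc(NC(=O)Nc4cccc(C(F)(F)F)c4)cc3)c(C)nc2cc1OC` gives 1290 nM in a functional assay on A498 cells (Homo sapiens) for inhibition, read by sulforhodamine B assay, with a stated time of 48 h; on this read-out higher numbers stand for weaker inhibition of growth and lower numbers for stronger inhibition of growth. Compound 2 `COc1cc2cc(Oc3ccc(NC(=O)Nc4ccc(Cl)c(C(F)(F)F)c4)cc3)c(C)nc2cc1OC` gives 754 nM in this assay. The change from the first to the second, chloro in place of hydrogen on an aromatic carbon, gave a 1.7-fold lower number from compound 1 to compound 2 (0.23 log units; within the scatter), so the two numbers cannot be told apart with confidence. Among the two, compound 2 sits at the low end, but its gap to compound 1 lies within the scatter.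

The next compound, compound 3 `COc1cc2cc(Oc3ccc(NC(=O)Nc4ccc(Cl)c(Cl)c4)cc3)c(C)nc2cc1OC`, differs from compound 2 by chloro in place of trifluoromethyl on an aromatic carbon. Among the compounds with values here, no measured step swaps these two groups; the only step at hand, a 1.7-fold lower number from compound 1 to compound 2 (0.23 log units; within the scatter), concerns a different change and was itself within the scatter, so it gives no direction. Compound 3 is therefore expected to give about 900 nM in this assay, with a range from 350 nM to 2500 nM, meaning that the step of a 1.2-fold higher number from compound 2 to compound 3 (0.08 log units; within the scatter) is expected.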

Compound 3, concentration for 50% growth inhibition: 1950 nM
Beside the measured number, compound 3's estimate is 2.2-fold (0.34 log units) below it; low and high end bracket the measured number.
By their numbers in this assay, from the lowest: compounds 2, 1 and 3 (each within the scatter of the next, the first and the last beyond it).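

Within the data shown here, with a chloro group already on the ring, this is the first change here to step beyond the scatter: putting chloro in place of trifluoromethyl, ortho to that chloro group, gives a 2.6-fold higher number from compound 2 to compound 3 (0.41 log units; beyond the scatter) in this assay, so growth inhibition at this position is modestly stronger with trifluoromethyl. Without the comparison to compound 2 this would not show, since replacing the whole 3-(trifluoromethyl)phenyl with 3,4-dichlorophenyl gives a 1.5-fold higher number from compound 1 to compound 3 (0.18 log units; within the scatter), and those two numbers cannot be told apart. Nothing available explains why the two groups differ.

Still open, as far as these compounds go, is how other groups at this position, such as a nitrile, a methoxy or an amine, would compare with trifluoromethyl and chloro. Also open, from the compounds shown here alone, is whether the same swap would give a similar step on a ring without the second chloro group.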